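The source may hold more compounds than are shown below. What is called first, only, known or untested is meant among the compounds shown, and "the series" means these compounds.

Working notes on the series. Compound 1 `COC(c1cc(Cl)c2c(c1Cl)C(=O)N(Cc1c(C)cc(C)[nH]c1=O)CC2)C1CCOC1` has repeated entries in an assay for inhibition of histone-lysine N-methyltransferase EZH2 variant Y641N (Homo sapiens), read by scintillation counting, with a stated time of 60 min, in the presence of a further agent that is not named here (a higher number here means a weaker inhibitor, a lower number a stronger inhibitor), giving 130 nM; 30 nM; 1.9 nM; 0.6 nM (4 entries); the spread of these entries the several entries of compound 1 in this assay, 130 nM; 30 nM; 1.9 nM; 0.6 nM (4 entries) is wide, so any single reading in this assay is read with caution. Compound 2 `Cc1cc(C)c(CN2CCc3c(Cl)cc([C@H](CO)[C@@H]4CCCO4)c(Cl)c3C2=O)c(=O)[nH]1` in this assay gives 10 nM, the only number shown for it, alongside one further entry without a single value. Compound 3 `Cc1cc(C)c(CN2CCc3c(Cl)cc([C@@H](CO)[C@@H]4CCCO4)c(Cl)c3C2=O)c(=O)[nH]1` is not yet measured in this assay; it differs from compound 2 in configuration only (the two compounds have the same atoms and bonds and differ only in configuration as drawn: 1 of 2 stereo elements differ; a stereocentre at a saturated chain carbon is drawn R in compound 2 and S in compound 3), the stereocentre at a saturated chain carbon being drawn R in compound 2 and S in compound 3. For the measured compounds named here, no measured pair shows what inverting this centre does. The expectation is a modest loss for compound 3 relative to compound 2, with the step from compound 2 to compound 3 estimated at a 3.0-fold higher number from compound 2 to compound 3 (0.48 log units; beyond the scatter), though a step within the scatter cannot be excluded. Compound 3 is therefore estimated at 30 nM, with a range from 4 nM to 300 nM.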

Compound 3, inhibition constant: 135 nM
Estimate against measurement, compound 3: 4.5-fold (0.65 log units) below; the range from low to high includes it.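

For the compounds shown here, this is the first measured pair that isolates this stereocentre: in this assay, inverting the saturated chain carbon from R to S gives a 14-fold higher number from compound 2 to compound 3 (1.13 log units; beyond the scatter). The step is large and beyond the scatter, and it can be assigned to the inversion alone because nothing else separates the pair: the fact that compounds 2 and 3 differ only in the configuration as drawn. The size of the step still rests on single readings, which call for caution in this assay: the several entries of compound 1 in this assay, 130 nM; 30 nM; 1.9 nM; 0.6 nM (4 entries).

Still open, on these data alone, is the effect of inverting the other stereo element, which is the same in compound 2 and compound 3. Also open, as far as these compounds go, is whether the advantage of the configuration in compound 2 persists when the hydroxyl group on this chain is replaced by an amine or a carboxylic acid.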